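A second chlorine on the shared purine-like core

The source may report more compounds than this note shows. Statements on the series, on what has been measured and on what is new or still open speak of the compounds shown alone.

Of the compounds shown here, two have been measured in a functional assay on Hs-578T cells (Homo sapiens) for cytotoxicity, read by sulforhodamine B assay, with a stated time of 48 h; a higher number here means a weaker inhibitor of growth, a lower number a stronger inhibitor of growth. Compound 1 `ClCc1cccc(Cn2cnc3ncnc(Cl)c32)c1` gives 42700 nM, the higher of the two numbers. Compound 2 `ClCc1cccc(Cn2cnc3c(Cl)nc(Cl)nc32)c1` gives 4360 nM, and the gap between compound 1 and compound 2 lies beyond the scatter of this assay; since the two structures differ in more than one place, the comparison says only what the two values show.

Compound 3 `ClCc1cccc(Cn2cnc3nc(Cl)nc(Cl)c32)c1` is compound 1 with one change: chloro in place of hydrogen on an aromatic carbon. Among the measured compounds shown here, no measured pair differs in exactly this way, so the size of the step has to be guessed. Compound 3 shares with compound 2 a second chlorine on the core, and compound 2 gives 4360 nM, so the second chlorine in compound 3 is expected to be accompanied by a lower number in this assay rather than a higher one. The step from compound 1 to compound 3 is estimated as a 5.3-fold lower number from compound 1 to compound 3 (0.73 log units; beyond the scatter), a clear drop rather than a change within the scatter. Compound 3 is therefore expected to give about 8000 nM, with a range from 2500 nM to 25000 nM.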

Compound 3, concentration for total growth inhibition: 2810 nM
Beside the measured number, compound 3's estimate is 2.8-fold (0.45 log units) above it; the measured number falls inside the stated range.
By their numbers in this assay, from the lowest: compounds 3 and 2 (each within the scatter of the next); then compound 1.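

In this assay, among the compounds shown here, chloro in place of hydrogen on the aromatic carbon between two ring nitrogen atoms gives a large change (a 15-fold lower number from compound 1 to compound 3 (1.18 log units; beyond the scatter)), the first step in this set that can be tied to a single change. The gap between the first two compounds came with differences in more than one place, so it could not be assigned to any one of them, whereas here this one added chlorine, meta to the chloro group already on the core, accompanies the whole drop on its own. Nothing measured here accounts for the size of this step, and the data offer no reason for it.

The compounds shown leave open whether the step belongs to chloro in particular or would also appear with an amine, a methoxy group or a fluoro group on the same aromatic carbon. They also leave open what part the chloromethyl group plays, since all three compounds carry it, and whether the step would hold with a hydroxymethyl group in its place.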